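Removing one fluoro from the core of compound 1

The source may hold more compounds than are shown below. What is called first, only, known or untested is meant among the compounds shown, and "the series" means these compounds.

Compound 1 `O=c1c(-c2nn[nH]n2)c[nH]c2c(F)ccc(F)c12` has been measured in a functional assay on the whole organism (strain Sprague-Dawley) for inhibition, with Rattus norvegicus as the target (on this read-out higher numbers stand for an effect only at larger amounts of compound and lower numbers for an effect already at smaller amounts), and gives > 0.156 mg/kg, which is a limit of the assay and not a number. Compound 3 `O=c1c(-c2nn[nH]n2)c[nH]c2c(Cl)c(Cl)ccc12` in this assay gives > 0.156 mg/kg, again a limit rather than a number. Compound 2 `CCc1cccc2cc(C(=O)O)cnc12`, built on a different core, gives > 50 mg/kg in this assay, also a limit. For compound 1 only a limit is therefore known, and it sits at the limit of > 0.156 mg/kg in this assay, at which 2 of the 3 values shown sit. The remaining value sits at the limit of > 50 mg/kg in this assay, at which 1 of the 3 values shown sits. Within the data shown here, no step between two measured compounds that differ in a single place is known, so the change considered below has no measured counterpart.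

Compound 4 `O=c1c(-c2nn[nH]n2)c[nH]c2c(F)cccc12` differs from compound 1 by hydrogen in place of fluoro on an aromatic carbon. Since every value in this assay is a limit, neither a direction nor a size for this kind of change can be read from the measured compounds. The expectation is that the step that the limit leaves unreadable from compound 1 to compound 4 stays within the usual scatter, with no shift beyond it in either direction. Compound 4 is accordingly estimated at 0.3 mg/kg, between 0.1 mg/kg and 3 mg/kg, and it is expected that the assay will again report a limit rather than a number.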

Compound 4, minimum effective dose: 0.625 mg/kg
For compound 4 the middle estimate is 2.1-fold (0.32 log units) below the measured one; measured number inside the range.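

In this assay, among these compounds, compound 1 gives > 0.156 mg/kg, which is a limit of the assay and not a number, so no step to compound 4 can be read. The compounds shown leave open whether hydrogen in place of fluoro on an aromatic carbon of the shared core changes the read-out at all, and in which direction.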